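The source may hold more compounds than are shown below. What is called first, only, known or untested is meant among the compounds shown, and "the series" means these compounds.

In a functional assay for inhibition, with Rattus norvegicus as the target, at pH 7.35 (a higher number here means a weaker inhibitor, a lower number a stronger inhibitor), compound 1 `CCOC(=O)C(=O)C(CC)NC(=O)C(CC(C)C)NC(=O)OCc1ccccc1` gives 300000 nM and compound 2 `CCCCC(NC(=O)C(CC(C)C)NC(=O)OCc1ccccc1)C(=O)C(=O)OCC` gives 150000 nM (a gap within the scatter), so neither stands apart from the other. Compound 3 `CCC(NC(=O)C(CC(C)C)NC(=O)OCc1ccccc1)C(=O)C(=O)NCC(C)C` differs from compound 1 by isobutylamino in place of ethoxy on a carbonyl carbon. Within the data shown here, the only measured step (a 2.0-fold lower number from compound 1 to compound 2 (0.30 log units; within the scatter)) sits at a saturated chain carbon and not at this carbonyl carbon, so it offers little guidance here. The expected change (a 1.5-fold lower number from compound 1 to compound 3 (0.18 log units; within the scatter)) therefore stays within the scatter in this assay with no firm direction. For compound 3 the estimated value is 200000 nM with 30000 nM and 600000 nM as the expected ends of the range.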

Compound 3, half-maximal inhibitory concentration: 28000 nM
Compound 3: middle estimate off by 7.1-fold (0.85 log units), on the high side; measured number outside the range, below it.
By their numbers in this assay, from the lowest: compound 3; then compounds 2 and 1 (each within the scatter of the next).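

Among these compounds, at this carbonyl carbon, the change matters in this assay: isobutylamino in place of ethoxy gives an 11-fold lower number from compound 1 to compound 3 (1.03 log units; beyond the scatter), the first step here beyond the scatter. The swap changes two things at once, as the entering group has 5 heavy atoms against 3 and brings 1 hydrogen-bond donor where ethoxy has 0. No measurement available here gives a reason for this step.

Still open, from the compounds shown here alone, is how a smaller ethylamino or a carboxylic acid on this carbonyl carbon would read. Also open, going by these compounds, is whether isobutylamino gives a similar step on compound 2 .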